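Bromo to pyridin-3-yl in a permeable series

This account rests on a few compounds, and the source may have more. Where it says the series, first, only, none or still open, it means among the compounds named here.

Compound 1 `COC(=O)N[C@H](C(=O)NN(CCC[C@@](O)(Cc1ccccc1)C(=O)N[C@H]1c2ccccc2C[C@H]1O)Cc1ccc(Br)cc1)C(C)(C)C`: in an ADME assay on Caco-2 cells (Homo sapiens) for permeability, in the apical to basolateral direction (a higher number here means that the compound crosses the layer faster, a lower number that the compound crosses the layer more slowly), compound 1 gives > 20 10^-6 cm/s, which is a limit of the assay rather than a number.
Compound 2 `COC(=O)N[C@H](C(=O)NN(CCC[C@](O)(Cc1ccccc1)C(=O)N[C@H]1c2ccccc2C[C@H]1O)Cc1ccc(Br)cc1)C(C)(C)C`: in this assay compound 2 gives > 20 10^-6 cm/s, again a limit.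
Compound 3 `COC(=O)N[C@H](C(=O)NN(CCC[C@@](O)(Cc1ccccc1)C(=O)N[C@H]1c2ccccc2C[C@H]1O)Cc1ccc(-c2nccs2)cc1)C(C)(C)C`: in this assay compound 3 gives > 20 10^-6 cm/s, also a limit.

Compound 1 therefore stands at the upper edge of what this assay reports, and the two further values shown sit at the same edge, as the limit of > 20 10^-6 cm/s in this assay, at which 3 of the 3 values shown sit, records. Within the data shown here, the step that the two limits leave unreadable from compound 1 to compound 2 cannot be sized, and the same holds for a step that the two limits leave unreadable from compound 1 to compound 3: because the limit of > 20 10^-6 cm/s in this assay, at which 3 of the 3 values shown sit, every measured value is a limit, no step between these compounds can be read.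

Compound 4 `COC(=O)N[C@H](C(=O)NN(CCC[C@@](O)(Cc1ccccc1)C(=O)N[C@H]1c2ccccc2C[C@H]1O)Cc1ccc(-c2cccnc2)cc1)C(C)(C)C` is not yet measured. It differs from compound 1 by pyridin-3-yl in place of bromo on an aromatic carbon. Among the measured compounds shown here, of the measured steps, the one from compound 1 to compound 3 is the closest in kind, since it also puts an aromatic ring in place of bromo on the same aromatic carbon, yet its size is unreadable. No readable step is available, so no direction can be drawn from the data, and the expectation rests on the shared core and on the three limits already seen.

Compound 4 is expected to cross the cell layer quickly and to sit at or near the assay limit, so its estimated value is 25 10^-6 cm/s, with a range from 12 10^-6 cm/s to 45 10^-6 cm/s. The step that the limit leaves unreadable from compound 1 to compound 4 that this estimate implies is expected to fall within the usual scatter.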

Compound 4, apparent permeability: < 20 10^-6 cm/s
Compound 4 gave a limit, no number; the forecaster's own chance of this, stated with the estimate: 70%; middle value at least 1.2-fold (0.09 log units) from the limit.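

Among these compounds, until now every change left the value at the upper limit of this assay, so nothing showed that this aromatic carbon, para to a large group, could matter; compound 4 is the first compound here to leave that limit. Pyridin-3-yl in place of bromo gives a number no higher from compound 1 to compound 4 (the limit leaves the size open), and pyridin-3-yl in place of 1,3-thiazol-2-yl gives a number no higher from compound 3 to compound 4 (the limit leaves the size open). Two different aromatic rings on the same carbon thus end up on opposite sides of the limit, and compound 4 stands alone on its side: the limit of < 20 10^-6 cm/s in this assay, at which 1 of the 4 values shown sits.

Since all four values are limits, neither step can be sized, so the change could be large or could be small enough to lie within the usual scatter, and no cause can be named for it. From the compounds shown here alone, how a plain phenyl or a pyridin-4-yl on the same aromatic carbon would behave stays open, and with it whether the ring nitrogen of pyridin-3-yl or the added ring matters more.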